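From compound 1 to compound 4: a smaller side arm

This account rests on a few compounds, and the source may have more. Where it says the series, first, only, none or still open, it means among the compounds named here.

Three compounds of the series have numbers in an in vitro functional assay on cells for agonist activity at Bombesin receptor subtype-3 (Mus musculus), read by luminescence and calcium flux; a higher number here means that more compound is needed for the effect, a lower number that less compound is needed. Compound 1 `COc1ccccc1Cc1cnc(CCc2ccc(-c3ccccc3C(=O)O)cc2)[nH]1` gives 163 nM and stands lowest of the three. Compound 2 `CCCCc1cnc(CCCc2ccc(-c3ccccc3C(=O)O)cc2)[nH]1` gives 382 nM, a step beyond the scatter away from compound 1. Compound 3 `CCCCc1cnc(C(Cc2ccc(-c3ccccc3C(=O)O)cc2)C(C)C)[nH]1` gives 2240 nM, the furthest of the three from compound 1, well beyond the scatter.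

Compound 4 `CC(C)CCc1cnc(CCc2ccc(-c3ccccc3C(=O)O)cc2)[nH]1` is not yet measured. It differs from compound 1 in one place: isobutyl in place of 2-methoxyphenyl on a saturated chain carbon bound to an aromatic carbon. The 2-methoxyphenyl is lost and a short chain of four carbon atoms comes in on the saturated chain carbon bound to an aromatic carbon; no ring remains at that position.

Compound 2, which also carries a plain alkyl chain on the shared core, gives 382 nM, so a move toward a higher number is expected because compound 1 gives 163 nM. The step of a 3.1-fold higher number from compound 1 to compound 4 (0.49 log units; beyond the scatter) is expected to be moderate and beyond the scatter. Compound 4 is estimated at 500 nM, with a range from 150 nM to 1800 nM.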

Compound 4, half-maximal effective concentration: 10 nM
For compound 4 the middle estimate is 50-fold (1.70 log units) above the measured one, and the stated range ends above it.
By their numbers in this assay, from the lowest: compound 4; then compound 1; then compound 2; then compound 3.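

In this assay, the position on a saturated chain carbon bound to an aromatic carbon does not require the 2-methoxyphenyl: isobutyl in its place gives a 16-fold lower number from compound 1 to compound 4 (1.21 log units; beyond the scatter). For the compounds shown here, this is the first single-place comparison, and it shows that this position can move the number by a large step, and that the number falls even as an aromatic ring and a hydrogen-bond acceptor leave. Nothing in hand accounts for the size of this step.

The compounds shown leave open whether the lower number is specific to isobutyl or extends to other groups without an aromatic ring, such as a cyclohexyl or a longer chain. They also leave open whether an unsubstituted phenyl at this position would separate the contribution of the methoxy from that of the ring.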